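Pyrazoline series: methylamino in place of chloro

This account rests on a few compounds, and the source may have more. Where it says the series, first, only, none or still open, it means among the compounds named here.

Measured compounds in a functional assay on PC-3 cells (Homo sapiens) for cytotoxicity, read by MTT assay, with a stated time of 48 h; on this read-out lower numbers stand for stronger inhibition and higher numbers for weaker inhibition:
- compound 1 `CC1=NN(C(=O)c2ccc(C)cc2)C(c2ccccc2O)C1` gives 40600 nM
- compound 2 `Cc1ccc(C(=O)N2N=C(c3cc4ccccc4oc3=O)CC2c2ccccc2)cc1` gives 13200 nM
- compound 3 `O=C(CCl)N1N=C(c2cc3ccccc3oc2=O)CC1c1ccccc1` gives 2980 nM

Compound 3 stands lowest of the three numbers in this assay. Its nearest neighbour is compound 2, whose number is higher beyond the scatter, and compound 1 lies further off still. Among the measured compounds shown here, compound 1 and compound 2 have no step in common on one place, so their two values stand only side by side.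

For the measured compounds named here, the one step that touches the carbonyl substituent is a 4.4-fold lower number from compound 2 to compound 3 (0.65 log units; beyond the scatter). Going by the values given here, it is the only measured change at that place, and it bears on the next compound only loosely: compound 4 `CNCC(=O)N1N=C(c2cc3ccccc3oc2=O)CC1c1ccccc1` differs from compound 3 by methylamino in place of chloro on a saturated chain carbon bound to a carbonyl carbon. Among the compounds with values here, no measured pair shows this swap, and no pair shows a hydrogen-bond donor entering on this chain. The expectation therefore rests on the range spanned by compound 2 and compound 3 in this assay rather than on a matching step. The estimate is a modest upward step, a 2.0-fold higher number from compound 3 to compound 4 (0.30 log units; within the scatter), with the number landing between compound 3 and compound 2. For compound 4 the expected value in this assay is 6000 nM, with a range from 2000 nM to 20000 nM.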

Compound 4, half-maximal inhibitory concentration: 2300 nM
Estimate against measurement, compound 4: 2.6-fold (0.42 log units) above; measured number inside the range.
By their numbers in this assay, from the lowest: compounds 4 and 3 (each within the scatter of the next); then compound 2; then compound 1.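

In this assay the swap of chloro for methylamino on a saturated chain carbon bound to a carbonyl carbon gives a 1.3-fold lower number from compound 3 to compound 4 (0.11 log units; within the scatter) and so separates the two groups by no more than the scatter, which shows that the number seen with compound 3 does not depend on the chloro. The step of a 5.7-fold lower number from compound 2 to compound 4 (0.76 log units; beyond the scatter) stands beside a 4.4-fold lower number from compound 2 to compound 3 (0.65 log units; beyond the scatter) and gives a second case, among these three compounds only, in which a short chain on the carbonyl carbon reads beyond the scatter from 4-methylphenyl, with (methylamino)methyl now joining chloromethyl. Nothing at hand accounts for the two groups reading alike at this place.

Still open, going by these compounds, is how far this place tolerates other groups, such as a dimethylamino group, a morpholine, a carboxylic acid or a longer chain carrying the same amine. Also open, on these data alone, is whether chloro and methylamino would read alike on the core of compound 1, or in cell lines other than the one used in this assay for these compounds.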